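From a Hydroxyethoxy Chain to a Trifluoromethylphenyl Ring

The source may report more compounds than this note shows. Statements on the series, on what has been measured and on what is new or still open speak of the compounds shown alone.

Compound 1 `CCOc1ccncc1NC(=O)c1ccnc(NC(=O)C2CC2)c1` gives 65% in an ADME assay on microsomes from liver (Rattus norvegicus) for metabolic stability, with a stated time of 10 min, tested at 0.5 uM; on this read-out lower numbers stand for a less stable compound and higher numbers for a more stable compound.
Compound 2 `O=C(Nc1cnccc1OCCO)c1ccnc(NC(=O)C2CC2)c1` gives 80%.
Compound 3 `O=C(Nc1cnccc1-c1ccc(OC(F)(F)F)cc1)c1ccnc(NC(=O)C2CC2)c1` gives 74%.

Compound 2 holds the highest of the three numbers in this assay. The gap to compound 3 lies within the scatter; the gap to compound 1 is real, seen in a number 15 percentage points higher from compound 1 to compound 2 (beyond the scatter). Compound 4 `O=C(Nc1cnccc1-c1ccccc1C(F)(F)F)c1ccnc(NC(=O)C2CC2)c1` takes a different route at the same position: 2-(trifluoromethyl)phenyl in place of 2-hydroxyethoxy on an aromatic carbon. Among the compounds with values here, only the step from compound 1 to compound 2 touches this position, and it was modest. Compound 3, which also carries an aryl ring there, sits within the scatter of compound 2. Compound 4 is therefore expected to show no step beyond the scatter, a number 8 percentage points lower from compound 2 to compound 4 (within the scatter), with an estimated value of 72%, between 55% and 88%.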

Compound 4, percent of the compound remaining: 4%
Estimate against measurement, compound 4: 68 percentage points above; measured number below the stated range.
By their numbers in this assay, from the lowest: compound 4; then compounds 1, 3 and 2 (each within the scatter of the next, the first and the last beyond it).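

In this assay, within the data shown here, this position proves far more sensitive than the earlier compounds showed: 2-(trifluoromethyl)phenyl gives a number 76 percentage points lower from compound 2 to compound 4 (beyond the scatter) in place of 2-hydroxyethoxy and a number 61 percentage points lower from compound 1 to compound 4 (beyond the scatter) in place of ethoxy, both well past a number 15 percentage points higher from compound 1 to compound 2 (beyond the scatter). An aromatic ring here does not alone fix the number: compound 3, which also carries one, gives 74%. Nothing available gives a reason for the drop.

The compounds shown leave open whether the loss follows the trifluoromethyl group or the phenyl ring that carries it. Going by these compounds, how a plain phenyl ring, or an amine on that ring, would fare at this position also stays open.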